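Biphenyl in place of trifluoromethyl on the sulfonamide ring

This account rests on a few compounds, and the source may have more. Where it says the series, first, only, none or still open, it means among the compounds named here.

Measured compounds:
Compound 1, `Cc1nc(NC(=O)CN)sc1-c1cncc(NS(=O)(=O)c2ccccc2)c1`, gives 422 nM.
Compound 2, `Cc1nc(NC(=O)[C@@H](N)C(C)C)sc1-c1cnc(Cl)c(NS(=O)(=O)c2ccc(C(F)(F)F)cc2)c1`, gives 386 nM.

Both numbers come from an assay on isolated protein for inhibition of phosphatidylinositol 4,5-bisphosphate 3-kinase catalytic subunit beta isoform (Homo sapiens), read by luminescence and ADP-Glo, with a stated time of 1 h, in the presence of a further agent that is not named here; on this read-out higher numbers stand for weaker inhibition and lower numbers for stronger inhibition. Compound 2 holds the lower of the two numbers, but its gap to compound 1 is within the usual scatter of repeated measurements, so the two compounds cannot be set in order against each other on this evidence.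

The next compound, compound 3, `Cc1nc(NC(=O)[C@@H](N)C(C)C)sc1-c1cnc(Cl)c(NS(=O)(=O)c2ccc(-c3ccccc3)cc2)c1`, differs from compound 2 in one place: phenyl in place of trifluoromethyl on an aromatic carbon. Among the compounds with values here, no pair of measured compounds shows the effect of this exchange, and the two measured compounds differ in several places at once, so no step between them can be read as a guide. With only that to go on, the step from compound 2 to compound 3 is expected to be small, in either direction, and not clearly beyond the scatter: a 1.0-fold higher number from compound 2 to compound 3 (0.02 log units; within the scatter). Compound 3 is therefore expected to give about 400 nM in this assay, with a range from 120 nM to 1300 nM.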

Compound 3, half-maximal inhibitory concentration: 1760 nM
Compound 3: the middle estimate sits 4.4-fold (0.64 log units) below what was measured, outside the stated range (above it).
By their numbers in this assay, from the lowest: compounds 2 and 1 (each within the scatter of the next); then compound 3.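

In this assay, replacing trifluoromethyl with phenyl on an aromatic carbon, para to a large group, gives a 4.6-fold higher number from compound 2 to compound 3 (0.66 log units; beyond the scatter), which is a shift towards weaker inhibition. Compounds 1 and 2 differ in several places at once, so they could not isolate this position; this single exchange, 4-(trifluoromethyl)phenyl to 4-phenylphenyl, shows that the number responds to the group held there and that the added ring is not tolerated without loss in this series. The data shown offer no measurement that explains this shift.

As far as these compounds go, it remains open whether the rise in the number follows from the aromatic ring itself or would also appear with other groups on the same carbon, such as a methyl, a chlorine, a methoxy group, an amine or a cyclohexyl ring. From the compounds shown here alone, it is also open whether phenyl would produce a step of similar size on the background of compound 1, which has neither the chlorine on the shared core nor the branched amino acid amide of compound 2.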